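Ether for Nitrile at the Chain End

A few compounds are considered here, and "the series" means these few. Any claim that something is new, unique, unknown or untested is made for them only; others in the source may bear on it.

Two compounds share a core and a long phenyl-bearing chain; they differ only at the end of the shorter chain. Compound 1, `O=C(O)CCCCc1cnc(C(=O)CCCCCCc2ccccc2)o1`, carries a carboxy group there, and in an assay for inhibition of Fatty-acid amide hydrolase 1 (Rattus norvegicus), using a Dixon plot (a higher number here means a weaker inhibitor, a lower number a stronger inhibitor), compound 1 gives 23.8 nM. Compound 2, `N#CCCCCCc1cnc(C(=O)CCCCCCc2ccccc2)o1`, carries a cyano group instead, and in this assay compound 2 gives 4.8 nM. Among the measured compounds shown here, the step of a 5.0-fold lower number from compound 1 to compound 2 (0.70 log units; beyond the scatter) is the only measured step so far, and it leaves compound 2 with the lower of the two numbers, so compound 2 stands as the stronger of the pair.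

Compound 3, `COCOCCCCCc1cnc(C(=O)CCCCCCc2ccccc2)o1`, is the next step: methoxymethoxy in place of cyano on a saturated chain carbon, five bonds along the chain from an aromatic carbon. For the measured compounds named here, the one measured step shows that exchanging the chain-end group can move the number by a modest amount, but it compares carboxy against cyano, not cyano against an ether, so it bears on compound 3 only loosely. With no closer comparison available, the expected step is a 1.7-fold higher number from compound 2 to compound 3 (0.22 log units; within the scatter), towards a somewhat higher number but not clearly beyond the scatter. Compound 3 is therefore estimated to give 8 nM in this assay, with a range from 3 nM to 25 nM.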

Compound 3, inhibition constant: 24.1 nM
The estimate for compound 3 lay 3.0-fold (0.48 log units) below the measured number, and the stated range covers the measured number.
By their numbers in this assay, from the lowest: compound 2; then compounds 1 and 3 (each within the scatter of the next).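

In this assay, the nitrile of compound 2 is now set apart from two different chain ends rather than one: replacing it with methoxymethoxy gives a 5.0-fold higher number from compound 2 to compound 3 (0.70 log units; beyond the scatter) and so costs about as much as the carboxy end did. The two other chain ends, carboxy and methoxymethoxy, cannot be told apart here, for the comparison reads a 1.0-fold higher number from compound 1 to compound 3 (0.01 log units; within the scatter) and so gives them no order among these three compounds. Nothing measured on these compounds accounts for the nitrile giving the lowest number of the three.

A chain ending in an amine, an amide or a plain methyl group would show whether the low number is particular to the nitrile or is shared by other chain ends that are neither carboxy nor methoxymethoxy. A shorter or longer chain carrying the same nitrile would show whether the distance of that group from the shared core matters as much as the identity of the group itself.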